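Aryl for alkyl on the ring nitrogen of compound 2

The compounds below may be only part of what the source reports. "The series", "measured", "known", "first", "only" and "open" are said of these compounds alone.

Compound 2 `CCCCNc1nc(C(F)(F)F)ccc1CNC(=O)C(C)c1ccc(NS(C)(=O)=O)c(F)c1` is the reference point here. Within the data shown here, in a functional assay on CHO-K1 cells for antagonist activity at transient receptor potential cation channel subfamily V member 1 (Homo sapiens), read by FLIPR (on this read-out higher numbers stand for weaker inhibition and lower numbers for stronger inhibition), compound 2 gives 293 nM, the higher of the two numbers known, though its nearest neighbour sits within the scatter: compound 3 `CC(C(=O)NCc1ccc(C(F)(F)F)nc1NC1CCCCC1)c1ccc(NS(C)(=O)=O)c(F)c1` gives 260 nM. Compound 1 `CC(C(=O)NCc1ccc(C(F)(F)F)nc1)c1ccc(NS(C)(=O)=O)c(F)c1`, which lacks any group on that nitrogen, is reported as "not active" (no number reported). The measured step of a 1.1-fold lower number from compound 2 to compound 3 (0.05 log units; within the scatter) shows that exchanging one saturated group for another there leaves the number where it was. Compound 4 `Cc1ccc(Nc2nc(C(F)(F)F)ccc2CNC(=O)C(C)c2ccc(NS(C)(=O)=O)c(F)c2)cc1C` carries the change (3,4-dimethylphenyl in place of butyl on a nitrogen on an aromatic ring). Among the measured compounds shown here, no aromatic group has yet been tried in that place, so the single relevant step offers only weak guidance; a shift no larger than a 1.5-fold lower number from compound 2 to compound 4 (0.17 log units; within the scatter) is expected. Compound 4 is therefore estimated at 200 nM, within 60 nM to 700 nM.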

Compound 4, half-maximal inhibitory concentration: 1160 nM
The estimate for compound 4 lay 5.8-fold (0.76 log units) below the measured number; measured number outside the range, above it.
By their numbers in this assay, from the lowest: compounds 3 and 2 (each within the scatter of the next); then compound 4.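

In this assay, among these compounds, 3,4-dimethylphenyl is the only group on this nitrogen that moves the number beyond the scatter, with a 4.0-fold higher number from compound 2 to compound 4 (0.60 log units; beyond the scatter) and a 4.5-fold higher number from compound 3 to compound 4 (0.65 log units; beyond the scatter) as the two steps. Butyl and cyclohexyl could not be told apart, so this position does respond to the group placed on it, and here the aromatic group gives modestly weaker inhibition. Nothing available explains this shift.

Whether the ring itself or its two methyl groups account for the step remains open. A plain phenyl or a benzyl group on the same nitrogen would separate the two.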